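Triazole to imidazole swap on the shared core

The source may hold more compounds than are shown below. What is called first, only, known or untested is meant among the compounds shown, and "the series" means these compounds.

Numbers in a functional assay on HCT-116 cells (Homo sapiens) for cytotoxicity, read by MTT assay, with a stated time of 72 h; a higher number here means a weaker inhibitor, a lower number a stronger inhibitor:
compound 1 `COc1ncc(-c2ccc3nccc(-c4ccc(CN5CCN(C)CC5)cc4)c3c2)cc1NS(=O)(=O)c1ccc(F)cc1F`: 43.9 nM
compound 2 `COc1ncc(-c2ccc3nccc(-c4ccc(CN5CCN(C(C)C)CC5)cc4)c3c2)cc1NS(=O)(=O)c1ccc(F)cc1F`: 24.7 nM
compound 3 `COc1ncc(-c2ccc3nccc(-c4ccc(Cn5cncn5)cc4)c3c2)cc1NS(=O)(=O)c1ccc(F)cc1F`: 8.7 nM

Compound 3 holds the lowest number of the three in this assay. Its distance from compound 2 is a 2.8-fold lower number from compound 2 to compound 3 (0.45 log units; beyond the scatter) and from compound 1 it is a 5.0-fold lower number from compound 1 to compound 3 (0.70 log units; beyond the scatter); both of these steps exchange a piperazine for the triazole at the same place. The remaining step, a 1.8-fold lower number from compound 1 to compound 2 (0.25 log units; within the scatter), only changes the group on the piperazine nitrogen and stays within the scatter.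

Compound 4 `COc1ncc(-c2ccc3nccc(-c4ccc(Cn5ccnc5)cc4)c3c2)cc1NS(=O)(=O)c1ccc(F)cc1F` differs from compound 3 by 1H-imidazol-1-yl in place of 1H-1,2,4-triazol-1-yl on a saturated chain carbon bound to an aromatic carbon. For the measured compounds named here, no measured pair covers an exchange of one small azole for another; the two steps that reach compound 3 start from a piperazine, not from an azole, so they give no direct read on this move. Going by the values given here, with the five-membered aromatic ring, its attachment and its size kept, and only one ring nitrogen exchanged for a ring carbon, the expected step of a 1.1-fold higher number from compound 3 to compound 4 (0.06 log units; within the scatter) in this assay is none beyond the scatter. Compound 4 is therefore estimated at 10 nM in this assay, with a range from 4 nM to 25 nM.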

Compound 4, half-maximal inhibitory concentration: 32.6 nM
Compound 4: the middle estimate sits 3.3-fold (0.51 log units) below what was measured; the whole stated range lies below it.
By their numbers in this assay, from the lowest: compound 3; then compounds 2, 4 and 1 (each within the scatter of the next).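

In this assay the small azoles at this place are not interchangeable: the step of a 3.7-fold higher number from compound 3 to compound 4 (0.57 log units; beyond the scatter) follows from one ring nitrogen of the 1H-1,2,4-triazol-1-yl being exchanged for a ring carbon, with the attachment on the saturated chain carbon and the count of heavy atoms unchanged. The gain seen earlier on going from the piperazines to the triazole therefore does not extend to the 1H-imidazol-1-yl group, which stands level with both piperazines in the steps of a 1.3-fold higher number from compound 2 to compound 4 (0.12 log units; within the scatter) and a 1.3-fold lower number from compound 1 to compound 4 (0.13 log units; within the scatter) in this series, so that among these four compounds only compound 3 stands apart. No measurement at hand accounts for the difference between the two azoles.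

The compounds shown leave open how other five-membered azoles, such as 1H-pyrazol-1-yl, 1H-1,2,3-triazol-1-yl or 1H-tetrazol-1-yl, would fall relative to compound 3 and compound 4, and so whether the number or the placement of the ring nitrogens tracks the change. Also open, as far as these compounds go, is whether the gap between the two azoles would persist with a longer chain in place of the single saturated carbon.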